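Shortening the Aromatic Group While Keeping the Longer Chain

This account rests on a few compounds, and the source may have more. Where it says the series, first, only, none or still open, it means among the compounds named here.

Compound 1 `O=c1ccc(-n2cnc3ccccc32)nn1CCCCCCN1CCN(c2ccccc2Cl)CC1` was tested in an assay on cell membranes from brain for binding affinity to Adrenergic receptor alpha-1 (Rattus norvegicus), read by radioligand binding (on this read-out lower numbers stand for stronger inhibition and higher numbers for weaker inhibition), where compound 1 gives 15.1 nM. A second compound, compound 2 `O=c1ccc(-n2ccnc2)nn1CCCCCN1CCN(c2ccccc2Cl)CC1`, which carries the smaller 1H-imidazol-1-yl group on the shared core together with a shorter chain to the piperazine, was tested in the same way; in this assay compound 2 gives 23.3 nM. Among the measured compounds shown here, compound 1 thus holds the lower of the two numbers so far, but the gap to compound 2 lies within the usual scatter of repeated measurements, so no order between them can be claimed.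

Compound 3 `O=c1ccc(-n2ccnc2)nn1CCCCCCN1CCN(c2ccccc2Cl)CC1` has not yet been measured. It differs from compound 1 in one place: 1H-imidazol-1-yl in place of 1H-benzimidazol-1-yl on an aromatic carbon. For the measured compounds named here, no measured pair shows this exact change on its own. The account rests on compound 2, which already carries the 1H-imidazol-1-yl group and gives 23.3 nM, a number close to that of compound 1. The step of a 1.5-fold higher number from compound 1 to compound 3 (0.16 log units; within the scatter) is therefore expected to be small, with no change beyond the scatter. Compound 3 is estimated at 22 nM, with a range from 9 nM to 55 nM.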

Compound 3, inhibition constant: 29.7 nM
The estimate for compound 3 lay 1.4-fold (0.13 log units) below the measured number, and the stated range covers the measured number.
By their numbers in this assay, from the lowest: compounds 1, 2 and 3 (each within the scatter of the next).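

In this assay, among the compounds shown here, putting 1H-imidazol-1-yl in place of 1H-benzimidazol-1-yl on an aromatic carbon of the shared core, with the rest of compound 1 kept as it is, gives a 2.0-fold higher number from compound 1 to compound 3 (0.29 log units; within the scatter) and so gives the first direct reading of this change on its own. The six-membered aromatic ring of carbon only, which leaves with the 1H-benzimidazol-1-yl group, can thus go from this position without a difference that can be claimed on this read-out, although the step reaches the edge of the usual scatter. Nothing available bears on what lies behind the size of this step.

The compounds shown cover only these two groups at this position, so it remains open whether a plain phenyl ring, a morpholine, an amine or a carboxylic acid on the same aromatic carbon would also stay within the scatter of compound 1. On these data alone, it also remains open whether the same exchange of groups would give a similar step on a shorter or a longer chain to the piperazine.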